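This account rests on a few compounds, and the source may have more. Where it says the series, first, only, none or still open, it means among the compounds named here.

Working notes on the series. In a functional assay on MCF7 cells (Homo sapiens) for antiproliferative activity, read by sulforhodamine B assay, with a stated time of 48 h (on this read-out lower numbers stand for stronger inhibition and higher numbers for weaker inhibition), compound 1 `Cc1cccc(NS(=O)(=O)c2ccc(N3CCNC3=O)cc2)c1` gives 190 nM and compound 2 `Cc1cccc(NS(=O)(=O)c2ccc(N3CCNC3=O)cc2)c1C` gives 230 nM. These two values lie within the scatter of each other, so compound 1 cannot be ranked apart from compound 2.

Compound 3 `O=C1NCCN1c1ccc(S(=O)(=O)Nc2cccc(Oc3ccccc3)c2)cc1` keeps the core of compound 1 and carries phenoxy in place of methyl on an aromatic carbon, meta to a large group: phenoxy in place of methyl on an aromatic carbon.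

Among the measured compounds shown here, only one measured step bears on this change: a 1.2-fold higher number from compound 1 to compound 2 (0.08 log units; within the scatter). That step is methyl in place of hydrogen on an aromatic carbon, and it stayed within the scatter. It is a weak guide, as it adds a single methyl, whereas the change to compound 3 brings in a whole ring. For the measured compounds named here, no measured compound carries phenoxy, so the direction remains open. No step beyond the scatter is expected in this assay, though the uncertainty is wide. The estimate corresponds to an expected 1.5-fold higher number from compound 1 to compound 3 (0.17 log units; within the scatter). For compound 3 the expected value is 280 nM, with an estimated range from 70 nM to 1100 nM.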

Compound 3, half-maximal inhibitory concentration: 220 nM
Compound 3: middle estimate off by 1.3-fold (0.10 log units), on the high side; the measured number falls inside the stated range.
By their numbers in this assay, from the lowest: compounds 1, 3 and 2 (each within the scatter of the next).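

Phenoxy in place of methyl on an aromatic carbon, meta to a large group, gives a 1.2-fold higher number from compound 1 to compound 3 (0.06 log units; within the scatter) in this assay, so even this much larger replacement does not separate compound 3 from compound 1. The earlier pair covered only the addition of a single methyl, whereas this step brings in a whole six-membered aromatic ring of carbon only and a hydrogen-bond acceptor, and the number still cannot be told apart from that of the methyl compound; across compounds 1, 2 and 3, the substituents shown on this ring leave the read-out within the scatter, with no compound going against that. No measurement is at hand that could explain this tolerance of the change.

The compounds shown leave open whether a charged or hydrogen-bond-donating group at this place, such as an amine or a carboxylic acid, would stay within the same range as the methyl and phenoxy groups. Going by these compounds, it also remains open whether a longer chain, or a substituent on the phenoxy ring itself, would move the number beyond the scatter.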